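The source may report more compounds than this note shows. Statements on the series, on what has been measured and on what is new or still open speak of the compounds shown alone.

In a functional assay (aorta) with Oryctolagus cuniculus as the target (on this read-out lower numbers stand for stronger inhibition and higher numbers for weaker inhibition), the measured compounds are:

Compound 1 `CO/C(O)=C1\C(C)=NC(C)=C(C(=O)OCCCN2C(=O)c3ccccc3S2(=O)=O)C1c1ccccc1[N+](=O)[O-]` 1.5 nM
Compound 2 `CO/C(O)=C1\C(C)=NC(C)=C(C(=O)OCCCN2C(=O)c3ccccc3S2(=O)=O)C1c1cccc(Cl)c1Cl` 0.8 nM

Compound 2 and compound 1 lie within the scatter of each other. Compound 3 `CC1=NC(C)=C(C(=O)OCCCN2C(=O)c3ccccc3S2(=O)=O)C(c2cccc(Cl)c2Cl)/C1=C(\O)OCC1CCCCO1` differs from compound 2 by oxan-2-yl in place of hydrogen on a saturated chain carbon bound to an oxygen on an unsaturated carbon and carries oxan-2-yl in place of hydrogen on a saturated chain carbon bound to an oxygen on an unsaturated carbon, so methoxy becomes (oxan-2-yl)methoxy. Going by the values given here, the only measured step, a 1.9-fold lower number from compound 1 to compound 2 (0.27 log units; within the scatter) within the scatter, places 2,3-dichlorophenyl in place of 2-nitrophenyl on a saturated ring carbon. It does not test this change, so no direction can be drawn from the data, and no shift beyond the scatter is expected in this assay for now. The expected change is a 1.5-fold higher number from compound 2 to compound 3 (0.18 log units; within the scatter) and carries little weight. For compound 3 the expected value is 1.2 nM and 0.3 nM to 6 nM is the estimated range.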

Compound 3, half-maximal inhibitory concentration: 4 nM
Compound 3: the middle estimate sits 3.3-fold (0.52 log units) below what was measured; the range from low to high includes it.
By their numbers in this assay, from the lowest: compounds 2 and 1 (each within the scatter of the next); then compound 3.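

In this assay, replacing methoxy with (oxan-2-yl)methoxy gives a 5.0-fold higher number from compound 2 to compound 3 (0.70 log units; beyond the scatter), the only step shown that lies beyond the scatter. This shows that the number responds to a change at this saturated chain carbon bound to an oxygen on an unsaturated carbon, and that adding oxan-2-yl here moves it modestly upward. Nothing available explains the shift. As far as these compounds go, it remains open how ethoxy or a (piperidin-2-yl)methoxy group would read here, and whether the step would hold with 2-nitrophenyl in place of 2,3-dichlorophenyl.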